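Adding a sulfanyl group to compound 2

The source may hold more compounds than are shown below. What is called first, only, known or untested is meant among the compounds shown, and "the series" means these compounds.

In an ADME assay on S9 fraction from liver (Rattus norvegicus, strain Wistar) for metabolic stability, read by HPLC, using NADPH, tested at 20 uM (a lower number here means that the compound disappears faster, a higher number that the compound lasts longer), compound 1 (`O=C(Nc1nc2ccccc2s1)c1ccc(OC(F)F)c(OCC2CC2)c1`) gives 0.705 h and compound 2 (`O=C(Nc1ccc2ncsc2c1)c1ccc(OC(F)F)c(OCC2CC2)c1`) gives 1.05 h, two values within the usual scatter of each other. Compound 3 (`O=C(Nc1ccc2nc(S)sc2c1)c1ccc(OC(F)F)c(OCC2CC2)c1`) has sulfanyl in place of hydrogen on an aromatic carbon, next to the ring nitrogen and next to the ring sulfur: sulfanyl in place of hydrogen on an aromatic carbon. Among the measured compounds shown here, the only measured step, a 1.5-fold higher number from compound 1 to compound 2 (0.17 log units; within the scatter), exchanges 1,3-benzothiazol-2-yl for 1,3-benzothiazol-6-yl and involves no sulfanyl group, so it offers no basis for expecting a shift beyond the scatter. The expected change is a 1.2-fold lower number from compound 2 to compound 3 (0.07 log units; within the scatter). Compound 3 is estimated at 0.9 h, with an expected range of 0.4 h to 2 h.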

Compound 3, half-life: 4.13 h
Estimate against measurement, compound 3: 4.6-fold (0.66 log units) below, and the stated range ends below it.
By their numbers in this assay, from the lowest: compounds 1 and 2 (each within the scatter of the next); then compound 3.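

In this assay, sulfanyl in place of hydrogen on an aromatic carbon, next to the ring nitrogen and next to the ring sulfur, gives a 3.9-fold higher number from compound 2 to compound 3 (0.59 log units; beyond the scatter) and so shows that the half-life responds to a single substitution at this position, whereas the earlier pair stayed within the scatter. Nothing measured here bears on why the number moves. From the compounds shown here alone, whether an amine or a methyl group at the same carbon would move the number likewise remains open, as does whether a methylsulfanyl group would keep the longer half-life of compound 3.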